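Hydrazone series: methylcarbamoyl takes the place of fluoro

The compounds below may be only part of what the source reports. "The series", "measured", "known", "first", "only" and "open" are said of these compounds alone.

Compound 1 `CC1CC/C(=N\Nc2ccc(F)cc2)c2ncc(C(=O)O)c(=O)n21` reaches in a functional assay on the whole organism for inhibition, with Rattus norvegicus as the target (on this read-out higher numbers stand for an effect only at larger amounts of compound and lower numbers for an effect already at smaller amounts), only a limit, > 1000 umol/kg. Compound 2 `CC1CC/C(=N\Nc2ccccc2[N+](=O)[O-])c2ncc(C(=O)O)c(=O)n21` likewise gives in this assay only a limit, > 1000 umol/kg. For the measured compounds named here, both known values sit at the same limit (the limit of > 1000 umol/kg in this assay, at which 2 of the 2 values shown sit), so no measured step exists and compound 1 cannot be placed relative to compound 2. Compound 3 `CNC(=O)c1ccc(N/N=C2\CCC(C)n3c2ncc(C(=O)O)c3=O)cc1` carries the change (methylcarbamoyl in place of fluoro on an aromatic carbon). With both measured compounds at the limit, no direction can be read from the data, and the step of a number no higher from compound 1 to compound 3 (the limit leaves the size open) is expected to stay within the scatter. Compound 3 is estimated at 1000 umol/kg, within 300 umol/kg to 3000 umol/kg, most probably reported again only as a limit.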

Compound 3, dose for 50% inhibition: > 100 umol/kg
Compound 3: a limit, no number; the forecaster's own chance of this, stated with the estimate: 70%; the middle value is on the limit's open side.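

Compound 3 gives only a limit in this assay, > 100 umol/kg. For the compounds shown here, compound 1 also gives only a limit, > 1000 umol/kg, so no step from compound 1 to compound 3 can be read. The compounds shown leave open whether methylcarbamoyl in place of fluoro shifts the read-out at all.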